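This account rests on a few compounds, and the source may have more. Where it says the series, first, only, none or still open, it means among the compounds named here.

Three compounds share one core and differ only in the group on an amine nitrogen in a ring. Compound 1 `Nc1ccccc1NC(=O)c1ccc(CSC(=S)N2CCN(Cc3ccccn3)CC2)cc1` carries a (pyridin-2-yl)methyl there; in a functional assay on MGC-803 cells (Homo sapiens) for antiproliferative activity, read by CCK-8 assay, with a stated time of 72 h, tested at 8 uM (a higher number here means a stronger effect of the compound at the concentration tested, a lower number a weaker effect), compound 1 gives 65.2%. Compound 2 `Nc1ccccc1NC(=O)c1ccc(CSC(=S)N2CCN(c3ccccc3)CC2)cc1` carries a phenyl, and compound 2 gives 87.4%. Compound 3 `N#Cc1ccc(N2CCN(C(=S)SCc3ccc(C(=O)Nc4ccccc4N)cc3)CC2)cc1` carries a 4-cyanophenyl, and compound 3 gives 37.6%, the lowest of the three numbers; the nearest is compound 1 and the furthest compound 2, both beyond the scatter. Compound 4 `Nc1ccccc1NC(=O)c1ccc(CSC(=S)N2CCN(c3ncccn3)CC2)cc1` is the next step from compound 3: pyrimidin-2-yl in place of 4-cyanophenyl on an amine nitrogen in a ring. All three measured steps bear on it, since all sit at this nitrogen. The step of a number 22.2 percentage points higher from compound 1 to compound 2 (beyond the scatter) and the step of a number 27.6 percentage points lower from compound 1 to compound 3 (beyond the scatter) show that exchanges here move the number in either direction, and the step of a number 49.8 percentage points lower from compound 2 to compound 3 (beyond the scatter), the largest seen, turns on the cyano alone. For the measured compounds named here, compound 4 also gives up the cyano while keeping an aromatic ring directly on the nitrogen, so a rise is expected, though pyrimidin-2-yl has no measured counterpart and the size is uncertain. The expected step is a number 24.4 percentage points higher from compound 3 to compound 4 (beyond the scatter). Compound 4 is therefore estimated at 62%, within a range from 38% to 86%.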

Compound 4, a percentage reported as inhibition, at one concentration (the size of the read-out at that concentration, not a potency): 64.8%
Compound 4: middle estimate off by 2.8 percentage points, on the low side; low and high end bracket the measured number.
By their numbers in this assay, from the lowest: compound 3; then compounds 4 and 1 (each within the scatter of the next); then compound 2.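

In this assay, the exchange of 4-cyanophenyl for pyrimidin-2-yl gives a number 27.2 percentage points higher from compound 3 to compound 4 (beyond the scatter), which shows that an aromatic ring directly on this amine nitrogen can carry a much higher number than the 4-cyanophenyl allows. That ring still does not match the plain phenyl, with a number 22.6 percentage points lower from compound 2 to compound 4 (beyond the scatter), so among the three directly attached rings shown, the phenyl alone reaches the top level, and a change within the ring itself moves the number even when no nitrile is present. The directly attached pyrimidin-2-yl and the (pyridin-2-yl)methyl differ in both ring and link but cannot be told apart here, with a number 0.4 percentage points lower from compound 1 to compound 4 (within the scatter), and nothing among the data shown accounts for any of these differences.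

The compounds shown leave open whether the ring nitrogens of the pyrimidin-2-yl matter one by one, which a pyridin-2-yl placed directly on the nitrogen would address, and whether a benzyl would separate the effect of the methylene link from that of the ring. They also leave open whether the fall seen with the nitrile extends to other groups on the phenyl, such as fluoro or methoxy.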